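The compounds below may be only part of what the source reports. "The series", "measured", "known", "first", "only" and "open" are said of these compounds alone.

Compound 3 `COc1ccc(C2OC(c3cc(OC)c(OC)c(OC)c3)=NN2C(C)=O)c(OC)c1` carries a 2,4-dimethoxyphenyl group on a saturated ring carbon of the shared core. Among the compounds with values here, in a functional assay on BGC-823 cells (Homo sapiens) for antiproliferative activity, read by MTT assay, tested at 1 uM (a lower number here means a weaker effect, a higher number a stronger effect of the compound at the concentration tested), compound 3 gives 6.3%, the highest of the three numbers so far, yet within the scatter of both other members. Compound 2 `COc1cc(C2=NN(C(C)=O)C(c3cccc(OC)c3OC)O2)cc(OC)c1OC` gives 3.8% in this assay, and compound 1 `COc1cc(C2=NN(C(C)=O)C(c3cc(Cl)cc(Cl)c3)O2)cc(OC)c1OC` gives 0%. The steps between them are all small: a number 3.8 percentage points higher from compound 1 to compound 2 (within the scatter), a number 6.3 percentage points higher from compound 1 to compound 3 (within the scatter), and a number 2.5 percentage points higher from compound 2 to compound 3 (within the scatter). Within the data shown here, no compound in this set is separated from another beyond the scatter, so no order among them can be read from these numbers.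

Compound 4 `COc1ccc(OC)c(C2OC(c3cc(OC)c(OC)c(OC)c3)=NN2C(C)=O)c1` is the next member. The change from compound 3 to compound 4 is 2,5-dimethoxyphenyl in place of 2,4-dimethoxyphenyl on a saturated ring carbon. The step that bears most directly on it is the earlier exchange of one dimethoxyphenyl for another, a number 2.5 percentage points higher from compound 2 to compound 3 (within the scatter), which stayed within the scatter; the two steps from compound 1 did likewise. The expectation for this assay is therefore no step beyond the scatter: compound 4 is estimated to move by a number 0.3 percentage points lower from compound 3 to compound 4 (within the scatter). On that basis compound 4 is expected to give about 6% in this assay, within a range from 0% to 16%.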

Compound 4, a percentage reported as inhibition, at one concentration (the size of the read-out at that concentration, not a potency): 0.4%
For compound 4 the middle estimate is 5.6 percentage points above the measured one, within the range that was stated.
By their numbers in this assay, from the lowest: compounds 1, 4, 2 and 3 (each within the scatter of the next).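

In this assay the 2,5-dimethoxyphenyl group adds a further dimethoxyphenyl pattern on the saturated ring carbon, and the steps of a number 5.9 percentage points lower from compound 3 to compound 4 (within the scatter) and a number 3.4 percentage points lower from compound 2 to compound 4 (within the scatter) show that this exchange among dimethoxyphenyl groups again stays inside the scatter. The exchange against the chlorinated group, a number 0.4 percentage points higher from compound 1 to compound 4 (within the scatter) for this same new group, stays inside it as well, so the three dimethoxyphenyl groups and the 3,5-dichlorophenyl group cannot be told apart at this position at the one concentration tested. No measurement at hand bears on why these four numbers lie so close together.

Open, from the compounds shown here alone, is whether any group on this saturated ring carbon can move the number beyond the scatter, for example a phenyl ring carrying an amine or a carboxylic acid, or a longer chain in place of the aryl group. Also open, going by these compounds, is whether a change elsewhere on the shared core, such as a longer chain in place of the acetyl group, would separate these compounds.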